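Removing a Fluorine from a Carbamate Lipase Inhibitor

The source may hold more compounds than are shown below. What is called first, only, known or untested is meant among the compounds shown, and "the series" means these compounds.

Compound 2 `N#Cc1ccc(F)c(OC(=O)N2CCC(C(c3ccccc3)c3ccccc3)CC2)c1` is the weaker of the two measured compounds: in an assay on isolated protein for inhibition of Monoglyceride lipase (Rattus norvegicus), read by fluorescence, with stated times of 15 min and 3 h (a higher number here means a weaker inhibitor, a lower number a stronger inhibitor), compound 2 gives 112 nM, whereas compound 1 `N#Cc1ccnc(OC(=O)N2CCC(C(c3ccccc3)c3ccccc3)CC2)c1` gives 20.1 nM, and a 5.6-fold higher number from compound 1 to compound 2 (0.75 log units; beyond the scatter). Compound 3 `N#Cc1cccc(OC(=O)N2CCC(C(c3ccccc3)c3ccccc3)CC2)c1` differs from compound 2 by hydrogen in place of fluoro on an aromatic carbon. No measured step removes a fluoro on its own; the single step shown swaps the whole aromatic group, so it bears only loosely on this change. A small shift in this assay is therefore expected, possibly none beyond the scatter. Compound 3 is estimated at 150 nM, within 50 nM to 450 nM. That estimate means a 1.3-fold higher number from compound 2 to compound 3 (0.13 log units; within the scatter) is expected.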

Compound 3, half-maximal inhibitory concentration: 36.5 nM
For compound 3 the middle estimate is 4.1-fold (0.61 log units) above the measured one; measured number outside the range, below it.
By their numbers in this assay, from the lowest: compounds 1 and 3 (each within the scatter of the next); then compound 2.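

On this aromatic carbon, ortho to a large group and para to a cyano group, fluoro cannot be treated as interchangeable with hydrogen: in this assay the change gives a 3.1-fold lower number from compound 2 to compound 3 (0.49 log units; beyond the scatter). With fluoro gone, 3-cyanophenyl and 4-cyanopyridin-2-yl can no longer be told apart, with a 1.8-fold higher number from compound 1 to compound 3 (0.26 log units; within the scatter), so the gap in the earlier step does not persist. Nothing available explains this effect of fluoro. Still open, from the compounds shown here alone, is whether chloro or methoxy on the same carbon would track fluoro or hydrogen.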